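The source may report more compounds than this note shows. Statements on the series, on what has been measured and on what is new or still open speak of the compounds shown alone.

Of the compounds shown here, three have been measured in a functional assay on MDA-MB-435 cells (Homo sapiens) for inhibition, read by sulforhodamine B assay, with a stated time of 48 h; a higher number here means a weaker inhibitor of growth, a lower number a stronger inhibitor of growth. Compound 1 `N#C/C(=C\N1CCN(C(=O)c2ccco2)C1=S)C(=O)Nc1ccc(Cl)cc1` gives 15200 nM, compound 2 `N#C/C(=C\N1CCN(C(=O)c2ccco2)C1=S)C(N)=O` gives 14600 nM, and compound 3 `O=CN1CCN(c2ccc(Cl)cc2)C1=S` gives 14800 nM. Among the compounds with values here, the single step between compounds that differ in one place, a 1.0-fold lower number from compound 1 to compound 2 (0.02 log units; within the scatter), puts a hydrogen in place of a 4-chlorophenyl group on an amide-type nitrogen and leaves the number essentially where it was. Compound 3 stands second highest of the three numbers, with compound 2 nearest and compound 1 furthest, both within the scatter, so the three numbers cannot be told apart.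

Compound 4 `O=CN1CCN(c2ccc(Cl)c(Cl)c2)C1=S` has not yet been measured. Compared with compound 3 it carries chloro in place of hydrogen on an aromatic carbon, that is, chloro in place of hydrogen on an aromatic carbon. Within the data shown here, no measured step in this set alters a substituent on an aromatic ring; the step from compound 1 to compound 2 concerns a different part of the molecule and was within the scatter, so it offers no guide of its own beyond showing how little the number moved there. With nothing pointing either way, the expected step of a 1.1-fold lower number from compound 3 to compound 4 (0.02 log units; within the scatter) is none beyond the scatter. Compound 4 is therefore estimated at 14000 nM in this assay, with a range from 5500 nM to 36000 nM.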

Compound 4, concentration for 50% growth inhibition: 16600 nM
For compound 4 the middle estimate is 1.2-fold (0.07 log units) below the measured one, and the stated range covers the measured number.
By their numbers in this assay, from the lowest: compounds 2, 3, 1 and 4 (each within the scatter of the next).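

Placing a chloro group on an aromatic carbon of the six-membered ring, ortho to the chloro group already there and meta to the group of 8 heavy atoms, gives a 1.1-fold higher number from compound 3 to compound 4 (0.05 log units; within the scatter) in this assay. Within the data shown here, this is the first measured change on the aromatic ring itself, and like the earlier change on the amide-type nitrogen, it stays within the usual scatter, so one chlorine atom in place of hydrogen at this position does not tell the two compounds apart in growth inhibition. Nothing available here offers an explanation for this result.

Still open, going by these compounds, is whether a different group on this same carbon, such as a methoxy group, an amine or a carboxylic acid, would carry the number beyond the scatter. On these data alone, it is also open whether any change on this ring can move the number at all, as a single small substituent at a single position is too little to settle that.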